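This account rests on a few compounds, and the source may have more. Where it says the series, first, only, none or still open, it means among the compounds named here.

Measured compounds:
compound 1, `Fc1cccc(F)c1C#Cc1cccc2[nH]ncc12`: 96.2%
compound 2, `Fc1cccc(F)c1C#Cc1cnc2ccccc2c1`: 90.4%

Both compounds were tested in a functional assay on LS174T cells (Homo sapiens) for inhibition, with a stated time of 4 days, tested at 10 uM; a lower number here means a weaker effect, a higher number a stronger effect of the compound at the concentration tested. Compound 1 gives 96.2% there, and compound 2 gives 90.4%. The two numbers sit within the scatter of each other, so compound 2 cannot be set apart from compound 1 on this read-out; on the two numbers shown, compound 2 simply sits alongside compound 1 near the top of what the assay can report.

The step now followed leads from compound 2 to compound 3, `Fc1cccc(F)c1C#Cc1cc2ccccc2nc1Cl`. The change is chloro in place of hydrogen on an aromatic carbon. Among the compounds with values here, no comparable step between measured compounds is available, so there is nothing in the measured pairs that would show what a chloro in this place does. With compound 2 already giving a high percentage, the room for a larger number is small, and a step of a number 2.4 percentage points lower from compound 2 to compound 3 (within the scatter) is expected, a change not beyond the scatter in either direction. Compound 3 is therefore estimated to give 88% in this assay, with a range from 70% to 97%.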

Compound 3, a percentage reported as inhibition, at one concentration (the size of the read-out at that concentration, not a potency): 85.1%
Beside the measured number, compound 3's estimate is 2.9 percentage points above it, and the stated range covers the measured number.
By their numbers in this assay, from the lowest: compounds 3, 2 and 1 (each within the scatter of the next, the first and the last beyond it).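

In this assay, chloro in place of hydrogen on an aromatic carbon, next to the ring nitrogen and ortho to a large group, gives a number 5.3 percentage points lower from compound 2 to compound 3 (within the scatter) and so leaves the read-out unchanged within the scatter. Within the data shown here, this is the first pair that differs in one place, and it shows that this position of compound 2 can carry a chloro without a measurable loss of inhibition at the single concentration tested. Nothing available explains this outcome or says what the chloro does at this position.

On these data alone, the pair covers only hydrogen and chloro at this position, so it remains open whether a methyl, a methoxy, an amine or a carboxylic acid placed here would also leave the read-out unchanged or would move it beyond the scatter. As far as these compounds go, compound 2 and compound 3 also both sit high in a read-out taken at one concentration, so any difference in potency between them that this percentage cannot show remains open as well.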